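This account rests on a few compounds, and the source may have more. Where it says the series, first, only, none or still open, it means among the compounds named here.

Working notes on the series. In a functional assay on HeLa cells (Homo sapiens) for cytotoxicity, read by WST assay, with a stated time of 48 h (on this read-out higher numbers stand for weaker inhibition and lower numbers for stronger inhibition), compound 1 `COc1ccc([C@@H]2OC[C@H]([C@@H](O)c3ccc(OC)c(OC)c3)C[C@H]2C/C=C/c2ccc(OC)c(OC)c2)cc1` gives 29200 nM; compound 2 `COc1ccc(/C=C/C[C@@H]2C[C@@H]([C@@H](O)c3ccc(OC)c(OC)c3)CO[C@H]2c2ccccc2)cc1OC` gives 16100 nM; compound 3 `COc1ccc([C@H]2OC[C@H]([C@@H](O)c3ccc(OC)c(OC)c3)C[C@@H]2C/C=C/c2ccc(OC)c(OC)c2)cc1` gives 46700 nM. The step of a 1.8-fold higher number from compound 2 to compound 1 (0.26 log units; within the scatter) corresponds to the change (methoxy in place of hydrogen on an aromatic carbon). The step of a 1.6-fold higher number from compound 1 to compound 3 (0.20 log units; within the scatter) rests on (the fact that compounds 1 and 3 differ only in the configuration as drawn). Compound 4 `COc1ccc(/C=C/C[C@H]2C[C@@H]([C@@H](O)c3ccc(OC)c(OC)c3)CO[C@@H]2c2ccc(OC)c(OC)c2)cc1OC` is still to be measured in this assay. From compound 3 it differs by methoxy in place of hydrogen on an aromatic carbon; set against the change from compound 2 to compound 1, the place now reads ortho to a methoxy group and meta to a large group rather than para to a large group, so this is the same kind of change, not the same. The difference between the cores of compound 2 and compound 3 is not broken down here. Given the earlier step of a 1.8-fold higher number from compound 2 to compound 1 (0.26 log units; within the scatter), the step from compound 3 to compound 4 is expected to be about a 1.4-fold higher number from compound 3 to compound 4 (0.14 log units; within the scatter). Compound 4 is therefore estimated at 65000 nM, in a range from 30000 nM to 150000 nM.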

Compound 4, half-maximal inhibitory concentration: 23800 nM
For compound 4 the middle estimate is 2.7-fold (0.44 log units) above the measured one; measured number outside the range, below it.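

In this assay the added methoxy gives a 2.0-fold lower number from compound 3 to compound 4 (0.29 log units; within the scatter), and set against the earlier step, the change does not carry over from one core to the other as a single fixed shift: the same change on two cores in this assay, a 1.8-fold higher number (0.26 log units; within the scatter) from compound 2 to compound 1 and a 2.0-fold lower number (0.29 log units; within the scatter) from compound 3 to compound 4, 3.6-fold (0.55 log units) apart, beyond the scatter of two such steps. Each step on its own lies within the scatter, so neither shows a real effect of the methoxy on its core; only the gap between them goes beyond it. With one pair per core, and the methoxy not in the same place in the two pairs, the data do not show what sets the steps apart.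

The compounds shown leave open how a hydroxy group, a fluorine atom or an amine on that aromatic carbon would read on either core.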